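The compounds below may be only part of what the source reports. "The series", "measured", "known", "first", "only" and "open" are said of these compounds alone.

Compound 1 `Oc1cccc(-c2cc(-c3cccc(F)c3)cc(-c3ccccc3O)n2)c1` is recorded in a functional assay on DU-145 cells (Homo sapiens) for inhibition (on this read-out higher numbers stand for weaker inhibition and lower numbers for stronger inhibition), only as a limit, > 50000 nM. Compound 2 `Oc1cccc(-c2cc(-c3ccccc3F)cc(-c3cccc(O)c3)n2)c1` gives 11200 nM in this assay.

Compound 2 thus stands as the only numbered result here; the other entry is a limit (the limit of > 50000 nM in this assay, at which 1 of the 2 values shown sits). Compound 3 `Oc1cccc(-c2cc(-c3cccc(F)c3)cc(-c3cccc(O)c3)n2)c1` differs from compound 2 in one place: 3-fluorophenyl in place of 2-fluorophenyl on an aromatic carbon. Among the compounds with values here, no measured pair isolates this change, so the expected step from compound 2 to compound 3 is taken as a 1.0-fold lower number from compound 2 to compound 3 (0.01 log units; within the scatter), which is none beyond the usual scatter. Compound 3 is therefore estimated at 11000 nM, within 4000 nM to 40000 nM.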

Compound 3, half-maximal inhibitory concentration: 23800 nM
Estimate against measurement, compound 3: 2.2-fold (0.34 log units) below, and the stated range covers the measured number.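

In this assay, 3-fluorophenyl in place of 2-fluorophenyl on the aromatic carbon opposite the ring nitrogen gives a 2.1-fold higher number from compound 2 to compound 3 (0.33 log units; beyond the scatter), so the place of the fluorine on this ring changes the read-out modestly. With 3-fluorophenyl kept, 3-hydroxyphenyl in place of 2-hydroxyphenyl gives an at least 2.1-fold lower number from compound 1 to compound 3 (0.32 log units; beyond the scatter), so the place of the hydroxyl counts as well. This second step starts from a limit for compound 1, not a number: the limit of > 50000 nM in this assay, at which 1 of the 3 values shown sits.

The compounds shown leave open how an amine or a carboxylic acid on this phenyl ring would read, and whether a 4-fluorophenyl group would follow the same direction.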